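The source may report more compounds than this note shows. Statements on the series, on what has been measured and on what is new or still open speak of the compounds shown alone.

Of the compounds shown here, two have been measured so far in a functional assay on the whole organism (blood) with Rattus norvegicus as the target, at a dose of 100 mg/kg by the oral route; on this read-out lower numbers stand for less inhibition and higher numbers for more inhibition at the one dose given (going by the name of the read-out). Compound 1, `Cc1ccc(N2CCN(CC(O)COc3ccc(C#N)cc3)CC2C)cc1`, gives 40.3% in this assay. Compound 2, `N#Cc1ccc(OCC(O)CN2CCN(c3cccc(C(F)(F)F)c3)CC2)cc1`, gives 49.7% in this assay. Compound 2 stands highest of the two numbers, but the distance to compound 1 lies within the usual scatter of repeated measurements, so the two cannot be told apart with confidence.

The next compound, compound 3, `N#Cc1ccc(OCC(O)CN2CCN(c3cccc(Cl)c3)CC2)cc1`, differs from compound 2 in a single place: chloro in place of trifluoromethyl on an aromatic carbon. Among the compounds with values here, no step between two measured compounds is available for this kind of change, so there is no measured pattern to lean on. The expectation is that the step of a number 4.7 percentage points lower from compound 2 to compound 3 (within the scatter) stays within the scatter, in no particular direction. Compound 3 is therefore estimated to give 45% in this assay, with a likely range from 25% to 65%.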

Compound 3, a percentage reported as inhibition, in the whole organism at one dose (the size of the read-out at that dose, not a potency): 16.5%
Beside the measured number, compound 3's estimate is 28.5 percentage points above it, outside the stated range (below it).
By their numbers in this assay, from the lowest: compound 3; then compounds 1 and 2 (each within the scatter of the next).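

In this assay the group on this aromatic carbon, meta to a large group, clearly matters: putting chloro in place of trifluoromethyl gives a number 33.2 percentage points lower from compound 2 to compound 3 (beyond the scatter). The earlier compounds shown here could not show this, as compound 1 and compound 2 differ in more than one place and no single change could be read from them. Nothing available explains why this one change has so large an effect.

Within the data shown here, only two groups have been compared at this position, so it stays open whether a methoxy group or an amine in the same place would give a number closer to that of compound 2 or to that of compound 3. As far as these compounds go, it is also open whether the same change would give a step of similar size on the core of compound 1.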